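Fluoro substitution on the benzoyl ring: working notes

A few compounds are considered here, and "the series" means these few. Any claim that something is new, unique, unknown or untested is made for them only; others in the source may bear on it.

Measured compounds:
compound 1 `COc1ccc(-c2cc3ccccc3nc2C=O)cc1` — > 10000 nM
compound 2 `COc1ccc(-c2cc3ccccc3nc2/C=C/C(=O)c2ccccc2)cc1` — 4040 nM

Within the data shown here, in a functional assay on MCF7 cells (Homo sapiens) for antiproliferative activity, read by XTT assay, with a stated time of 72 h (on this read-out lower numbers stand for stronger inhibition and higher numbers for weaker inhibition), compound 2 gives 4040 nM, the only numerical value in the set so far. For compound 1 the read-out is a limit, not a number: compound 1 sits at the limit of > 10000 nM in this assay, at which 1 of the 2 values shown sits.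

Compound 3 `COc1ccc(-c2cc3ccccc3nc2/C=C/C(=O)c2ccc(F)cc2)cc1` has not yet been measured. It differs from compound 2 by fluoro in place of hydrogen on an aromatic carbon — fluoro in place of hydrogen on an aromatic carbon of a six-membered aromatic ring of carbon only, para to a large group; read one bond further out, benzoyl becomes (4-fluorophenyl)carbonyl. Among the measured compounds shown here, no step between measured compounds exists to size this kind of change, so the expectation rests on compound 2 alone. The step from compound 2 to compound 3 is expected to be a 1.3-fold lower number from compound 2 to compound 3 (0.10 log units; within the scatter), within the usual scatter, with no clear direction. Compound 3 is therefore estimated at 3200 nM in this assay, with a range from 1200 nM to 8500 nM.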

Compound 3, half-maximal inhibitory concentration: 5450 nM
Beside the measured number, compound 3's estimate is 1.7-fold (0.23 log units) below it; measured number inside the range.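

In this assay, among these compounds, the one step at the benzoyl ring reads a 1.3-fold higher number from compound 2 to compound 3 (0.13 log units; within the scatter), the first measure of any change on this ring. Phenyl to 4-fluorophenyl, with fluoro para to a large group, therefore leaves compound 2 and compound 3 indistinguishable on this read-out, and the position shows no direction for this change. No measurement shown bears on why the step is this size.

Going by these compounds, it remains open whether an amine, a hydroxyl or a carboxylic acid in place of the fluoro would give a step beyond the scatter. On these data alone, with a single step, it is also open whether fluoro would read the same on compounds with a longer chain joining the benzoyl ring to the shared core.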